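This account rests on a few compounds, and the source may have more. Where it says the series, first, only, none or still open, it means among the compounds named here.

Compound 1, whose structure is `Cc1ccc(C(=O)NC2=C(C#N)C(c3ccc(Cl)cc3Cl)C3=C(CCCC3=O)N2c2ccc(S(N)(=O)=O)cc2)cc1`, was tested in a functional assay on Ehrlich cells (Mus musculus) for cytotoxicity, read by trypan blue exclusion, with a stated time of 2 h, tested at 25 ug/mL (on this read-out higher numbers stand for a stronger effect at the one concentration tested and lower numbers for a weaker effect), and gave 30%. Two other compounds built on the shared core were measured in this assay alongside it. Compound 2, with the structure `NC1=C(C(=O)O)C(c2ccc(Cl)cc2Cl)C2=C(CCCC2=O)N1c1ccc(S(N)(=O)=O)cc1`, gave 0% in this assay. Compound 3, with the structure `N#CC1=C(/N=C/c2ccc([N+](=O)[O-])cc2[N+](=O)[O-])N(c2ccc(S(N)(=O)=O)cc2)C2=C(C(=O)CCC2)C1c1ccc(Cl)cc1Cl`, gave 20% in this assay. On these three numbers compound 1 stands highest; the number for compound 3 lies within the usual scatter of such measurements, while the number for compound 2 lies beyond it.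

Compound 4, with the structure `CCO/C=N/C1=C(C#N)C(c2ccc(Cl)cc2Cl)C2=C(CCCC2=O)N1c1ccc(S(N)(=O)=O)cc1`, has not yet been measured. It differs from compound 1 in one place: a group of 5 heavy atoms (3 carbon, 1 nitrogen, 1 oxygen; no ring) in place of a group of 10 heavy atoms (8 carbon, 1 nitrogen, 1 oxygen; one six-membered aromatic ring of carbon only), on a double-bonded ring carbon. For the measured compounds named here, no measured pair in this set shows this change, so there is no step to lean on. The expectation for compound 4 rests on what compound 3 gives, 20%, with its own group on the same place, and on what compound 1 gives, 30%. The step from compound 1 to compound 4 in this assay is estimated as a number 10 percentage points lower from compound 1 to compound 4 (within the scatter), not beyond the scatter. Compound 4 is therefore expected to give about 20% in this assay, with a range from 5% to 40%.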

Compound 4, a percentage reported as activity, at one concentration (the size of the read-out at that concentration, not a potency): 30%
The estimate for compound 4 lay 10 percentage points below the measured number, and the stated range covers the measured number.
By their numbers in this assay, from the lowest: compound 2; then compounds 3, 1 and 4 (each within the scatter of the next).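

In this assay, the open group of compound 4, which has no ring, stands on the double-bonded ring carbon in place of ((4-methylphenyl)carbonyl)amino and gives no change at the digits printed from compound 1 to compound 4 (within the scatter), so this position accepts both groups without a change that can be told from the scatter. Ethoxy in place of 2,4-dinitrophenyl on the carbon with a double bond to nitrogen gives a number 10 percentage points higher from compound 3 to compound 4 (within the scatter), so that exchange also leaves the read-out within the scatter. Nothing available explains why these different groups read alike.

As far as these compounds go, whether a butoxy chain on that same carbon, or a morpholine ring at the double-bonded ring carbon, would keep this level remains open. A single concentration also leaves open how these compounds compare in potency.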